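Methyl for Trifluoromethyl on a Thiazole-Type Core

The source may hold more compounds than are shown below. What is called first, only, known or untested is meant among the compounds shown, and "the series" means these compounds.

Measured compounds:
Compound 1 `Cc1nc(N(C)C(=O)NC(=O)c2c(F)cccc2F)sc1C(=O)N/N=C/c1cccc(C(F)(F)F)c1`: 26.8 ug/mL
Compound 2 `CN(C(=O)NC(=O)c1c(F)cccc1F)c1nc(C(F)(F)F)c(C(=O)N/N=C/c2ccc(C(F)(F)F)cc2)s1`: 30.6 ug/mL

Both compounds were tested in a functional assay on HeLa cells (Homo sapiens) for inhibition, read by MTT assay, with a stated time of 72 h; on this read-out lower numbers stand for stronger inhibition and higher numbers for weaker inhibition. Of the two numbers, compound 2 `CN(C(=O)NC(=O)c1c(F)cccc1F)c1nc(C(F)(F)F)c(C(=O)N/N=C/c2ccc(C(F)(F)F)cc2)s1` stands highest, but its nearest neighbour, compound 1, sits only a small distance away, and that gap lies within the usual scatter of repeated measurements, so the two cannot be ranked against each other. Both act only at high concentrations.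

Compound 3 `Cc1nc(N(C)C(=O)NC(=O)c2c(F)cccc2F)sc1C(=O)N/N=C/c1ccc(C(F)(F)F)cc1` has not yet been measured. It differs from compound 2 in a single place: methyl in place of trifluoromethyl on an aromatic carbon. The rest of the molecule is unchanged, and the core that results is the same core carried by compound 1.

Within the data shown here, no measured pair shows this particular exchange, so no measured step can be drawn upon. Given that compound 1 and compound 2 lie within scatter of each other, the step from compound 2 to compound 3 is expected to be a 1.1-fold lower number from compound 2 to compound 3 (0.04 log units; within the scatter), with no direction beyond the scatter. Compound 3 is therefore estimated at 28 ug/mL, in a range from 14 ug/mL to 56 ug/mL.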

Compound 3, half-maximal inhibitory concentration: 40.6 ug/mL
Compound 3: middle estimate off by 1.5-fold (0.16 log units), on the low side; the range from low to high includes it.
By their numbers in this assay, from the lowest: compounds 1, 2 and 3 (each within the scatter of the next).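

In this assay, methyl in place of trifluoromethyl on the aromatic carbon next to the ring nitrogen gives a 1.3-fold higher number from compound 2 to compound 3 (0.12 log units; within the scatter). Among these compounds, this is the first direct reading of that exchange: replacing a group of 4 heavy atoms with one of 1 heavy atom leaves the number within the scatter, so this pair shows no measurable effect of the change at this position. Compound 3 also adds a second comparison on the methyl-bearing core, where 4-(trifluoromethyl)phenyl in place of 3-(trifluoromethyl)phenyl gives a 1.5-fold higher number from compound 1 to compound 3 (0.18 log units; within the scatter), again too small a difference to separate the two compounds, and nothing available explains why either change has so little effect on the read-out.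

Going by these compounds, whether any other group on this ring carbon would shift the number beyond the scatter remains open, for example an amine, a carboxylic acid or a longer chain such as propyl. Also open, on these data alone, is whether the aromatic ring at the far end responds to a larger change, such as an amine or a carboxylic acid in place of trifluoromethyl.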